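A few compounds are considered here, and "the series" means these few. Any claim that something is new, unique, unknown or untested is made for them only; others in the source may bear on it.

Compound 1 `C=CCNC(=O)n1c(-c2ccc(OC)cc2)cc(=O)c2c(OC)cc(OC)cc21` and compound 2 `COc1ccc(-c2cc(=O)c3c(OC)cc(OC)cc3n2S(=O)(=O)c2cccc([N+](=O)[O-])c2)cc1` share one core but carry different groups on the ring nitrogen, and both were tested in an ADME assay on BJ cells (Homo sapiens) for antiproliferative activity, with a stated time of 72 h; on this read-out higher numbers stand for an effect only at larger amounts of compound and lower numbers for an effect already at smaller amounts. In this assay compound 1 gives 74000 nM. For compound 2 the result is not a number but a limit of the assay, > 39600 nM. Among the measured compounds shown here, compound 2 therefore stands at the edge of what this assay can report, as the limit of > 39600 nM in this assay, at which 1 of the 2 values shown sits, makes clear, and no step between two measured compounds is available for comparison.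

Compound 3 `COc1ccc(-c2cc(=O)c3c(OC)cc(OC)cc3n2S(=O)(=O)c2ccc(C#N)cc2)cc1` has not yet been measured in this assay. It differs from compound 2 by a single change: 4-cyanophenyl in place of 3-nitrophenyl on a sulfonyl sulfur. For the measured compounds named here, with compound 2 itself sitting at a limit, the data offer no measured step to lean on, and the expectation for the change from compound 2 to compound 3 is none beyond the scatter, with a real chance that compound 3 also returns only a limit. On that basis the estimated step is a step that the limit leaves unreadable from compound 2 to compound 3. Compound 3 is accordingly expected to give about 50000 nM in this assay, with a range from 20000 nM to 150000 nM.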

Compound 3, half-maximal effective concentration: > 17200 nM
Compound 3 ended at the assay's limit; the forecaster's own chance of this, stated with the estimate: 65%; the middle value is on the limit's open side.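

Compound 2 and compound 3 both returned only a limit of the assay in this assay, so no step can be read among compound 1, compound 2 and compound 3. The compounds shown leave open where the true values of compound 2 and compound 3 lie, and whether 4-cyanophenyl and 3-nitrophenyl on a sulfonyl sulfur differ at all.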